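A few compounds are considered here, and "the series" means these few. Any claim that something is new, unique, unknown or untested is made for them only; others in the source may bear on it.

Measured so far, in a functional assay on U-937 cells (Homo sapiens) for cytotoxicity, read by MTT assay, with a stated time of 24 h; on this read-out higher numbers stand for weaker inhibition and lower numbers for stronger inhibition:
- compound 1 `BrCCCCOc1c(Br)cc(Br)cc1Oc1ccc(Br)cc1Br`: 29 ug/mL
- compound 2 `CC(C)(C)OC(=O)N1CCN(CCCCCOc2c(Br)cc(Br)cc2Oc2ccc(Br)cc2Br)CC1`: 35.5 ug/mL

Compound 1 and compound 2 lie within the scatter of each other, so neither can be ranked above the other on these two numbers.

The next compound is compound 3 `CCOC(=O)C(C)Oc1c(Br)cc(Br)cc1Oc1ccc(Br)cc1Br`. Relative to compound 1 the change is 1-(ethoxycarbonyl)ethyl in place of 4-bromobutyl on an oxygen on an aromatic ring, which puts 1-(ethoxycarbonyl)ethyl in place of 4-bromobutyl on an oxygen on an aromatic ring. For the measured compounds named here, the measured compounds offer no single-place step to scale this change, so the only guide is the level set by compound 1 at 29 ug/mL and by compound 2 at 35.5 ug/mL. No shift beyond the scatter is expected, in either direction, and the estimated step is a 1.0-fold higher number from compound 1 to compound 3 (0.01 log units; within the scatter). For compound 3 the expected value in this assay is 30 ug/mL, with an estimated range of 12 ug/mL to 70 ug/mL.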

Compound 3, half-maximal inhibitory concentration: 39.5 ug/mL
Beside the measured number, compound 3's estimate is 1.3-fold (0.12 log units) below it; low and high end bracket the measured number.
By their numbers in this assay, from the lowest: compounds 1, 2 and 3 (each within the scatter of the next).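

For the compounds shown here, on the oxygen on an aromatic ring, 1-(ethoxycarbonyl)ethyl in place of 4-bromobutyl gives in this assay a 1.4-fold higher number from compound 1 to compound 3 (0.13 log units; within the scatter) and this is the first single-place step. The exchange takes out the bromine-bearing chain and brings in 2 hydrogen-bond acceptors and a double bond outside aromatic rings, yet it does not separate the two substituents on this read-out. Nothing measured on hand offers an explanation for this result.

Going by these compounds, it remains open whether a carboxylic acid in place of the ethoxycarbonyl, or an amine at the end of a chain on this oxygen, would move the number beyond the scatter. On these data alone, a longer chain ending in bromine on the same oxygen is equally open.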